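The compounds below may be only part of what the source reports. "The series", "measured", "known", "first", "only" and "open" are said of these compounds alone.

In a functional assay on MDA-MB-231 cells (Homo sapiens) for inhibition, read by MTT assay, with a stated time of 48 h (on this read-out lower numbers stand for stronger inhibition and higher numbers for weaker inhibition), compound 1 (`COc1cc(-c2nccn3cc(-c4ccc([N+](=O)[O-])cc4)nc23)cc(OC)c1OC`) gives > 10000 nM as its reading, which is a limit and not a number. Compound 2 (`COc1cc(-c2nccn3cc(-c4ccc(C(F)(F)F)cc4)nc23)cc(OC)c1OC`) gives > 10000 nM as its reading, also a limit. Among the measured compounds shown here, compound 2 therefore stands with the only other measured compound, as the limit of > 10000 nM in this assay, at which 2 of the 2 values shown sit, shows. Compound 3 (`COc1cc(-c2nccn3cc(-c4ccc(O)cc4)nc23)cc(OC)c1OC`) carries hydroxy in place of trifluoromethyl on an aromatic carbon, para to a large group (hydroxy in place of trifluoromethyl on an aromatic carbon). For the measured compounds named here, the only measured step that bears on this change (a step that the two limits leave unreadable from compound 1 to compound 2) has no readable size, so no step beyond the scatter is expected in this assay and neither direction is favoured. The expected step is estimated as (a number no higher from compound 2 to compound 3 (the limit leaves the size open)). Compound 3 is expected at about 10000 nM with an estimated range from 2500 nM to 40000 nM and may well be only a limit again.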

Compound 3, half-maximal inhibitory concentration: > 10000 nM
Compound 3: a limit, no number; the forecaster's own chance of this, stated with the estimate: 60%; the middle value lies on the limit itself.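

In this assay, among the compounds shown here, the readings of compound 1, compound 2 and compound 3 are all limits and not numbers, and no step among them can be read. The compounds shown leave open where each truly stands, and whether nitro, trifluoromethyl and hydroxy differ at all on this read-out.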